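The source may report more compounds than this note shows. Statements on the series, on what has been measured and on what is new or still open speak of the compounds shown alone.

Measured in a functional assay on MCF7 cells (Homo sapiens) for cytotoxicity, read by ELISA, with a stated time of 4 days; on this read-out higher numbers stand for weaker inhibition and lower numbers for stronger inhibition:
- compound 1 `Cc1ccc(-c2cc(-c3ccoc3)cc(-c3ccc(Cl)s3)n2)o1`: 1900 nM
- compound 2 `Clc1ccc(-c2cc(-c3ccoc3)cc(-c3ccccc3Cl)n2)s1`: 7360 nM

Of these two numbers, compound 2 holds the higher one at 7360 nM, which makes it the weaker inhibitor of the pair. Compound 3 `Clc1ccc(-c2cc(-c3ccoc3)cc(-c3ccccn3)n2)s1` has not been measured. It differs from compound 2 as follows: pyridin-2-yl in place of 2-chlorophenyl on an aromatic carbon. In words, this is pyridin-2-yl in place of 2-chlorophenyl on an aromatic carbon, next to the ring nitrogen.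

Going by the values given here, only one measured step bears on this carbon: a 3.9-fold higher number from compound 1 to compound 2 (0.59 log units; beyond the scatter). It is modest but beyond the scatter, with 2-chlorophenyl in place of 5-methylfuran-2-yl. Among the compounds with values here, no measured compound carries pyridin-2-yl, and two compounds establish no pattern, so the direction is uncertain. Going by a 3.9-fold higher number from compound 1 to compound 2 (0.59 log units; beyond the scatter), a modest step toward a lower number, no larger than that one, is expected in this assay. The expected step is a 2.1-fold lower number from compound 2 to compound 3 (0.32 log units; beyond the scatter). For compound 3 the estimated value is 3500 nM, with an expected range from 1000 nM to 12000 nM.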

Compound 3, half-maximal inhibitory concentration: 3360 nM
Beside the measured number, compound 3's estimate is 1.0-fold (0.02 log units) above it; low and high end bracket the measured number.
By their numbers in this assay, from the lowest: compounds 1 and 3 (each within the scatter of the next); then compound 2.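

In this assay, pyridin-2-yl in place of 2-chlorophenyl on this aromatic carbon gives a 2.2-fold lower number from compound 2 to compound 3 (0.34 log units; beyond the scatter) as a modest step, so a second change at the carbon next to the ring nitrogen now moves the number beyond the scatter. Pyridin-2-yl in place of 5-methylfuran-2-yl gives a 1.8-fold higher number from compound 1 to compound 3 (0.25 log units; within the scatter) and stays within the scatter, so these two groups are not separated in this assay, even though one is a six-membered ring and the other a five-membered ring bearing a methyl group. Of the three groups seen at this carbon, only 2-chlorophenyl stands apart from the other two, with the higher number, and no accompanying data bear on why this is so.

The compounds shown leave open whether a non-aromatic group at this carbon, such as morpholine or a simple amine, would keep the number in the same range or shift it in either direction. Going by these compounds, the furan-3-yl and 5-chlorothiophen-2-yl groups are the same throughout, so their contribution remains unknown, as does the effect of a carboxylic acid or a longer chain at either of those places.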